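A Urea Aryl Swap on a Shared Pyrazole Core

The compounds below may be only part of what the source reports. "The series", "measured", "known", "first", "only" and "open" are said of these compounds alone.

Two ureas built on one shared core have been tested in a functional assay on COLO 205 cells (Homo sapiens) for inhibition, read by sulforhodamine B assay, with a stated time of 48 h, tested at 0.01 uM; on this read-out lower numbers stand for a stronger effect and higher numbers for a weaker effect at the one concentration tested. Compound 1 `COc1cc(Cl)cc(-c2nn(-c3cccc(NC(=O)Nc4cc(C(F)(F)F)cc(C(F)(F)F)c4)c3)cc2-c2ccncc2)c1` gives 98%, and compound 2 `COc1cc(Cl)cc(-c2nn(-c3cccc(NC(=O)Nc4ccc(Cl)c(Cl)c4)c3)cc2-c2ccncc2)c1` gives 99%, a number that sits within the scatter of compound 1, so the two cannot be told apart. Compound 3 `COc1cc(Cl)cc(-c2nn(-c3cccc(NC(=O)Nc4cccc(C(F)(F)F)c4)c3)cc2-c2ccncc2)c1` differs from compound 2 in one place: 3-(trifluoromethyl)phenyl in place of 3,4-dichlorophenyl on an amide-type nitrogen. Neither measured compound shows an effect at this concentration, so the step from compound 2 to compound 3 is expected to be none beyond the scatter, a number 2 percentage points lower from compound 2 to compound 3 (within the scatter). Compound 3 is therefore estimated at 97%, between 85% and 105%.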

Compound 3, a percentage reported as activity, at one concentration (the size of the read-out at that concentration, not a potency): 100%
Beside the measured number, compound 3's estimate is 3 percentage points below it; measured number inside the range.
By their numbers in this assay, from the lowest: compounds 1, 2 and 3 (each within the scatter of the next).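

Across the aryl groups on this urea nitrogen, this assay still separates nothing: 3-(trifluoromethyl)phenyl in place of 3,4-dichlorophenyl gives a number 1 percentage points higher from compound 2 to compound 3 (within the scatter) while hydrogen in place of trifluoromethyl on an aromatic carbon gives a number 2 percentage points higher from compound 1 to compound 3 (within the scatter) at this one concentration. Neither the change of substituent pattern nor the loss of one trifluoromethyl produces a readable effect. No further data bear on this result. From the compounds shown here alone, whether a carboxylic acid or an amine on this phenyl ring, or a cyclohexyl group in its place, would lower the number stays open. So does the behaviour of these ureas at higher concentrations.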